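Moving a methyl group: 3,4-dimethylphenyl to 3,5-dimethylphenyl

The source may report more compounds than this note shows. Statements on the series, on what has been measured and on what is new or still open speak of the compounds shown alone.

Compound 1 `Cc1oc(-c2c(F)cccc2F)nc1CN1CCC(C(=O)NCCCN2C[C@H](C)C[C@H](C)C2)CC1` gives 0.35 h in an ADME assay on microsomes from liver (Rattus norvegicus) for metabolic stability, read by LC-MS, using NADPH, at 37 degrees C (a higher number here means that the compound lasts longer, a lower number that the compound disappears faster), as its half-life. Compound 2 `Cc1ccc(-c2nc(CN3CCC(C(=O)NCCCN4C[C@H](C)C[C@H](C)C4)CC3)c(C)o2)cc1C` gives > 0.5 h as a limit of the assay and not a number. Compound 3 `Cc1cc(C)cc(-c2nc(CN3CCC(C(=O)NCCCN4C[C@H](C)C[C@H](C)C4)CC3)c(C)o2)c1` has the same atoms joined differently, with 3,5-dimethylphenyl in place of 3,4-dimethylphenyl on an aromatic carbon. Among the measured compounds shown here, the one measured step at this place (an at least 1.4-fold higher number from compound 1 to compound 2 (0.15 log units; that floor lies within the scatter)) exchanged a different group and has a floor within the scatter, so no step beyond the scatter is expected in this assay here. The estimated change (a number no higher from compound 2 to compound 3 (the limit leaves the size open)) is small. Compound 3 is expected to give 0.5 h (estimated range 0.25 h to 1 h).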

Compound 3, half-life: < 0.5 h
Compound 3: only a limit was reported; the forecaster's own chance of this, stated with the estimate: 50%; the middle value sits exactly at the limit.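

In this assay compound 3 gives < 0.5 h, a limit of the assay and not a number. Compound 2 gives > 0.5 h, also a limit. Going from 3,4-dimethylphenyl to 3,5-dimethylphenyl therefore gives a number no higher from compound 2 to compound 3 (the limit leaves the size open) and shows that the arrangement of the two methyl groups can matter here. The steps to compound 3 from compound 2 and from compound 1 cannot be read in size.

Going by these compounds, how far apart compound 2 and compound 3 lie stays open. So does the outcome with another group at this place, such as a pyridyl ring or 3,5-dichlorophenyl.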